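Removing the amino group: from compound 3 to compound 4

A few compounds are considered here, and "the series" means these few. Any claim that something is new, unique, unknown or untested is made for them only; others in the source may bear on it.

Three compounds of the shared core have numbers in a functional assay on A549 cells (Homo sapiens), read by MTT assay, with a stated time of 72 h; on this read-out higher numbers stand for weaker inhibition and lower numbers for stronger inhibition. Compound 1 `C#Cc1cn([C@@H]2O[C@H](CO)[C@@H](O)[C@H]2O)c2ncnc(N(C)C)c12` gives 390 nM. Compound 2 `COc1ncnc2c1c(-c1cccs1)cn2[C@@H]1O[C@H](CO)[C@@H](O)[C@H]1O` gives 4850 nM in this assay. Compound 3 `C#Cc1cn([C@@H]2O[C@H](CO)[C@@H](O)[C@H]2O)c2nc(N)nc(OC)c12` returns only a limit in this assay, > 100000 nM, which is the edge of the assay and not a measured number; compound 3 therefore stands at the weak end of everything seen here, consistent with the limit of > 100000 nM in this assay, at which 1 of the 3 values shown sits.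

Compound 4 `C#Cc1cn([C@@H]2O[C@H](CO)[C@@H](O)[C@H]2O)c2ncnc(OC)c12` has not been measured. It differs from compound 3 by hydrogen in place of amino on an aromatic carbon, on an aromatic carbon of a six-membered aromatic ring with 2 nitrogen, between two ring nitrogen atoms, meta to a methoxy group. Among the compounds with values here, no pair of measured compounds shows this change alone, so the step rests on the surrounding numbers. Compound 4 is expected to inhibit considerably more strongly than compound 3, because compound 1 gives 390 nM and compound 2 gives 4850 nM with neither carrying an amino group. The expected step of an at least 66-fold lower number from compound 3 to compound 4 (1.82 log units; beyond the scatter) is large and toward stronger inhibition, well beyond the scatter. Compound 4 is estimated at 1500 nM, with a range from 300 nM to 10000 nM.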

Compound 4, half-maximal inhibitory concentration: 8160 nM
Estimate against measurement, compound 4: 5.4-fold (0.74 log units) below; the range from low to high includes it.
By their numbers in this assay, from the lowest: compound 1; then compounds 2 and 4 (each within the scatter of the next). At a limit, above all of these: compound 3.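

In this assay, within the data shown here, hydrogen in place of amino between two ring nitrogen atoms gives an at least 12-fold lower number from compound 3 to compound 4 (1.08 log units; beyond the scatter), the first direct reading of this change, and it is large and toward stronger inhibition. That size is only a lower bound, since compound 3 has a limit and not a number: the limit of > 100000 nM in this assay, at which 1 of the 4 values shown sits. With hydrogen at this position, the other substituents can be compared: methoxy in place of dimethylamino gives a 21-fold higher number from compound 1 to compound 4 (1.32 log units; beyond the scatter), a large step toward weaker inhibition, while ethynyl in place of thiophen-2-yl gives a 1.7-fold higher number from compound 2 to compound 4 (0.23 log units; within the scatter), which stays within the scatter.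

Still open, from the compounds shown here alone, is whether a small group other than hydrogen at this position, such as methyl or chlorine, would keep the inhibition of compound 4. Also open, going by these compounds, is whether methylamino in place of methoxy would come closer to compound 1.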